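Carbamoyl for Methyl on the Aryl Ring of Compound 2

The source may hold more compounds than are shown below. What is called first, only, known or untested is meant among the compounds shown, and "the series" means these compounds.

Measured compounds:
Compound 1, `CN(/N=N/c1ccc(C#N)cc1)C(=O)N[C@@H](CCC(=O)O)C(=O)O`, 2.17 h
Compound 2, `Cc1ccc(/N=N/N(C)C(=O)N[C@@H](CCC(=O)O)C(=O)O)cc1`, 7.63 h
Compound 3, `CCOC(=O)c1ccc(/N=N/N(C)C(=O)N[C@@H](CCC(=O)O)C(=O)O)cc1`, 2.89 h

In a physicochemical assay for metabolic stability, in phosphate buffer, at pH 7.4 (on this read-out lower numbers stand for a shorter-lived compound and higher numbers for a longer-lived compound), compound 2 gives 7.63 h, the highest of the three numbers measured. Its nearest neighbour is compound 3, and the step of a 2.6-fold lower number from compound 2 to compound 3 (0.42 log units; beyond the scatter) lies beyond the scatter; compound 1 lies further away, the step of a 3.5-fold higher number from compound 1 to compound 2 (0.55 log units; beyond the scatter) also being beyond the scatter. Between compound 1 and compound 3 the step of a 1.3-fold higher number from compound 1 to compound 3 (0.12 log units; within the scatter) stays within the scatter.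

Compound 4, `CN(/N=N/c1ccc(C(N)=O)cc1)C(=O)N[C@@H](CCC(=O)O)C(=O)O`, is not yet measured. It differs from compound 2 in one place: carbamoyl in place of methyl on an aromatic carbon, on an aromatic carbon of a six-membered aromatic ring of carbon only, para to a large group.

Among the measured compounds shown here, two measured steps bear on this change. Each time the methyl of compound 2 is exchanged for another group on that aromatic carbon, the number drops: to compound 3 by a 2.6-fold lower number from compound 2 to compound 3 (0.42 log units; beyond the scatter), and to compound 1, read in reverse, by a 3.5-fold higher number from compound 1 to compound 2 (0.55 log units; beyond the scatter). Both are modest steps beyond the scatter. Carbamoyl has not been measured, so its own effect is unknown; by analogy to these two exchanges a modest decrease in this assay is expected, as a 2.5-fold lower number from compound 2 to compound 4 (0.41 log units; beyond the scatter). Compound 4 is therefore estimated at 3 h, within the range 1.5 h to 6 h.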

Compound 4, half-life: 0.107 h
Compound 4: the middle estimate sits 28-fold (1.45 log units) above what was measured, outside the stated range (below it).
By their numbers in this assay, from the lowest: compound 4; then compounds 1 and 3 (each within the scatter of the next); then compound 2.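

At this aromatic carbon, the choice of group can matter far more than the earlier exchanges showed: in this assay, a 71-fold lower number from compound 2 to compound 4 (1.85 log units; beyond the scatter) is a large step, whereas the exchange of methyl for ethoxycarbonyl gave only a 2.6-fold lower number from compound 2 to compound 3 (0.42 log units; beyond the scatter) and stayed modest. Carbamoyl also stands apart from both of the other groups that lower the number, since amino in place of ethoxy on a carbonyl carbon gives a 27-fold lower number from compound 3 to compound 4 (1.43 log units; beyond the scatter) and carbamoyl in place of cyano gives a 20-fold lower number from compound 1 to compound 4 (1.31 log units; beyond the scatter), even though compound 1 and compound 3 lie within the scatter of each other. Nothing shown accounts for this sharp drop in half-life.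

The compounds shown leave open whether a methylcarbamoyl or dimethylcarbamoyl group on this aromatic carbon would stay near compound 4 or return towards compound 1 and compound 3. They also leave open where a carboxylic acid at the same place would fall, and whether the large loss belongs to the carbamoyl group alone.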